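The source may report more compounds than this note shows. Statements on the series, on what has been measured and on what is new or still open speak of the compounds shown alone.

Working notes on the series. Compound 3 `COc1cc(OC)cc(-c2ccc(C(=O)N(Cc3cccc(OCCCCCC(=O)O)c3)C(C)C)cc2)c1` is the reference point for the step considered here. In an ADME assay on HepG2 cells (Homo sapiens) for cytotoxicity, read by CellTiter-Glo and resazurin assay, with a stated time of 72 h (a higher number here means that more compound is needed for the effect, a lower number that less compound is needed), compound 3 reaches only the limit of the assay, > 26000 nM. Compound 1 `COc1cccc(-c2ccc(C(=O)N(Cc3cccc(OCCCCCC(=O)O)c3)C(C)C)cc2)c1` likewise gives only a limit in this assay, > 26000 nM. Compound 2 `Cc1nnc(-c2cccc(-c3ccc(C(=O)N(Cc4cccc(OCCCCCC(=O)O)c4)C(C)C)cc3)c2)o1` also stops at a limit in this assay, > 26000 nM. All three values sit at the limit of > 26000 nM in this assay, at which 3 of the 3 values shown sit, so the measured steps among them, a step that the two limits leave unreadable from compound 1 to compound 2, a step that the two limits leave unreadable from compound 1 to compound 3 and a step that the two limits leave unreadable from compound 2 to compound 3, have no readable size: the exchanges on the aromatic ring have not carried any member of the series below that limit. Compound 4 `CC(C)N(Cc1cccc(OCCCCCC(=O)O)c1)C(=O)c1ccc(-c2cccc(Cl)c2)cc1` is the next member, differing from compound 3 by 3-chlorophenyl in place of 3,5-dimethoxyphenyl on an aromatic carbon. Because every comparison so far ends at the limit of > 26000 nM in this assay, at which 3 of the 3 values shown sit, no step beyond the scatter is expected for this change, and the most likely outcome is again a limit rather than a number. The estimate for compound 4 in this assay is therefore 30000 nM, with a range from 15000 nM to 60000 nM. This estimate corresponds to an expected step that the limit leaves unreadable from compound 3 to compound 4.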

Compound 4, half-maximal effective concentration: > 21900 nM
Compound 4: no number, only a limit; the forecaster's own chance of this, stated with the estimate: 80%; the middle value lies beyond the limit too.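

In this assay compound 4 gives only the limit > 21900 nM and so its steps to compound 1, compound 2 and compound 3 cannot be read. The compounds shown leave open at what concentration any of them reaches the half-maximal effect on these cells, and whether the exchanges on the aromatic ring change it.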